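Chloro to Fluoro on the Aromatic Ring

The compounds below may be only part of what the source reports. "The series", "measured", "known", "first", "only" and "open" are said of these compounds alone.

Compound 1, `Cc1ncc([N+](=O)[O-])n1CCOc1ccc(F)cc1`: 102 ug/mL
Compound 2, `Cc1cc(OCCn2c([N+](=O)[O-])cnc2C)ccc1Cl`: 159 ug/mL

Both compounds were tested in a functional assay on HT-29 cells (Homo sapiens) for cytotoxicity, read by MTT assay, with a stated time of 24 h; a lower number here means a stronger inhibitor, a higher number a weaker inhibitor. Compound 1 gives 102 ug/mL and compound 2 gives 159 ug/mL. Compound 2 has the highest of the two numbers, but its gap to compound 1 lies within the usual scatter, so the two cannot be told apart. Compound 3, `Cc1cc(OCCn2c([N+](=O)[O-])cnc2C)ccc1F`, has not yet been measured. It differs from compound 2 in one place: fluoro in place of chloro on an aromatic carbon. Among the measured compounds shown here, no pair of measured compounds shows this exact change, so there is no measured step to lean on. Compound 1 also carries a fluoro group and gives 102 ug/mL, although compound 1 and compound 3 differ elsewhere as well. A small step is expected, a 1.3-fold lower number from compound 2 to compound 3 (0.12 log units; within the scatter), toward a lower number but not beyond the scatter. Compound 3 is estimated at 120 ug/mL, with a range from 60 ug/mL to 240 ug/mL.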

Compound 3, half-maximal inhibitory concentration: 140 ug/mL
Beside the measured number, compound 3's estimate is 1.2-fold (0.07 log units) below it; the measured number falls inside the stated range.
By their numbers in this assay, from the lowest: compounds 1, 3 and 2 (each within the scatter of the next).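

In this assay, among the compounds shown here, placing fluoro instead of chloro on the aromatic carbon ortho to a methyl group and para to a large group gives a 1.1-fold lower number from compound 2 to compound 3 (0.06 log units; within the scatter), so exchanging these two halogens at this position produces no step that can be told from the scatter. With fluoro in place, putting methyl instead of hydrogen on an aromatic carbon gives a 1.4-fold higher number from compound 1 to compound 3 (0.14 log units; within the scatter), so this second single change also stays within the scatter. Nothing available explains either result.

The compounds shown leave open whether an amine, a carboxylic acid or a bromo group at the chloro and fluoro position would move the number beyond the scatter. From the compounds shown here alone, it also remains open whether a longer chain joining the aromatic ring to the rest of the molecule would do so.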